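One Ring Exchanged on a Double-Bonded Chain

The source may hold more compounds than are shown below. What is called first, only, known or untested is meant among the compounds shown, and "the series" means these compounds.

Compound 1 `COC(=O)CC/C=C\CC[C@H]1C(=O)C[C@@H](O)[C@@H]1/C=C/CC(C)(O)CCC1CCC1` gives 0.00009 mg/kg
Compound 2 `COC(=O)CC/C=C\CC[C@H]1C(=O)C[C@@H](O)[C@@H]1/C=C/C[C@@](C)(O)/C=C/C1=CCCCC1` gives 0.0003 mg/kg

In a functional assay on the whole organism (stomach) with Canis familiaris (Canis lupus familiaris) as the target (on this read-out lower numbers stand for an effect already at smaller amounts and higher numbers for an effect only at larger amounts of compound), compound 2 stands at the higher of the two numbers (0.0003 mg/kg). Compound 1 lies lower (0.00009 mg/kg), and that gap is beyond the usual scatter.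

Compound 3 `COC(=O)CC/C=C\CC[C@H]1C(=O)C[C@@H](O)[C@@H]1/C=C/C[C@@](C)(O)/C=C/C1CCC1` has not yet been measured. It departs from compound 2 in one place: cyclobutyl in place of cyclohex-1-en-1-yl on a double-bonded chain carbon bound to a double-bonded chain carbon. Cyclobutyl stands in place of cyclohex-1-en-1-yl on a double-bonded chain carbon bound to a double-bonded chain carbon.

Going by the values given here, the data hold no step between measured compounds that differ in one place, so this change has no direct precedent. In this assay a small step is expected, probably none beyond the scatter, with a slight lean toward a lower number. That lean rests only on compound 1 (0.00009 mg/kg) holding the lower of the two numbers, which is weak support. The expected change is a 1.5-fold lower number from compound 2 to compound 3 (0.18 log units; within the scatter). For compound 3 the estimated value is 0.0002 mg/kg, with an expected range from 0.00005 mg/kg to 0.0008 mg/kg.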

Compound 3, dose for half-maximal effect: 0.00005 mg/kg
For compound 3 the middle estimate is 4.0-fold (0.60 log units) above the measured one, and the stated range covers the measured number.
By their numbers in this assay, from the lowest: compounds 3 and 1 (each within the scatter of the next); then compound 2.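

In this assay, cyclobutyl in place of cyclohex-1-en-1-yl on a double-bonded chain carbon bound to a double-bonded chain carbon gives a 6.0-fold lower number from compound 2 to compound 3 (0.78 log units; beyond the scatter), the first direct sign that the read-out responds to the ring carried at this place. The second step, 3-cyclobutyl-1-hydroxy-1-methylprop-2-en-1-yl in place of 3-cyclobutyl-1-hydroxy-1-methylpropyl on a saturated chain carbon bound to a double-bonded chain carbon, gives a 1.8-fold lower number from compound 1 to compound 3 (0.26 log units; within the scatter), which stays within the scatter, so with cyclobutyl in place this read-out does not separate the double-bonded chain from the saturated one. Nothing on hand offers a reason for either step.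

The change from compound 2 to compound 3 alters ring size and removes the ring's double bond together, so the two remain unseparated; a cyclohexyl group at this place would divide them. A cyclopentyl or phenyl ring would show whether the response follows ring size at all, and a saturated chain carrying cyclohex-1-en-1-yl would show whether the chain's double bond counts as little with that ring as it does with cyclobutyl.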